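Hydroxy to Amino: Expected Effect on Cell Growth Inhibition

The compounds below may be only part of what the source reports. "The series", "measured", "known", "first", "only" and "open" are said of these compounds alone.

Compound 1 `Oc1ccc(/C=C/c2cccc(O)c2)cc1` and compound 3 `Nc1ccc(/C=C/c2cccc(O)c2)cc1` differ in a single place: amino in place of hydroxy on an aromatic carbon. In a functional assay on MCF7 cells (Homo sapiens) for inhibition, read by MTT assay, with a stated time of 2 days (a lower number here means a stronger inhibitor, a higher number a weaker inhibitor), compound 1 gives 23 ug/mL, and compound 3 gives 24.8 ug/mL; the step of a 1.1-fold higher number from compound 1 to compound 3 (0.03 log units; within the scatter) is a small one. Compound 2 `COc1ccc(/C=C/c2ccccc2O)cc1` gives 17 ug/mL in this assay; how its core differs from the core of compound 1 is not broken down here. Compound 4 `COc1ccc(/C=C/c2ccccc2N)cc1` has not yet been measured. It differs from compound 2 by amino in place of hydroxy on an aromatic carbon. Among the compounds with values here, this is the same kind of change as the one from compound 1 to compound 3, though here the place is ortho to a large group rather than para to a group of 9 heavy atoms. Because the step of a 1.1-fold higher number from compound 1 to compound 3 (0.03 log units; within the scatter) stayed within the scatter, the expected step of a 1.1-fold higher number from compound 2 to compound 4 (0.05 log units; within the scatter) is also small. Compound 4 is therefore estimated at about 19 ug/mL, expected to lie between 9 ug/mL and 40 ug/mL.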

Compound 4, half-maximal inhibitory concentration: 0.4 ug/mL
For compound 4 the middle estimate is 48-fold (1.68 log units) above the measured one, and the stated range ends above it.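

Amino in place of hydroxy on the core of compound 2 gives a 43-fold lower number from compound 2 to compound 4 (1.63 log units; beyond the scatter) in this assay. The size of this change therefore does not carry over from one core to the other in this series, as the two steps set together show: the same change on two cores in this assay, a 1.1-fold higher number (0.03 log units; within the scatter) from compound 1 to compound 3 and a 43-fold lower number (1.63 log units; beyond the scatter) from compound 2 to compound 4, 46-fold (1.66 log units) apart, beyond the scatter of two such steps. Within the data shown here, with only two pairs, this shows that the core can matter a great deal, but not which difference between the cores is responsible or why.

From the compounds shown here alone, it remains open whether another group on that same aromatic carbon, such as a methylamino or an acetamide group, would give a step like this one. Whether the large step belongs to amino alone is also unsettled.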